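Chloro in place of trifluoromethyl on the pendant ring

The source may report more compounds than this note shows. Statements on the series, on what has been measured and on what is new or still open speak of the compounds shown alone.

Measured so far:
compound 1 `COc1ccc(-c2sc3ccccc3c2C=O)cc1`: 89%
compound 2 `O=Cc1c(-c2ccc(C(F)(F)F)cc2)sc2ccccc12`: 88%

Going by the values given here, in a functional assay on KB cells (Homo sapiens) for cytotoxicity, tested at 10 uM (on this read-out higher numbers stand for more inhibition at the one concentration tested (going by the name of the read-out) and lower numbers for less inhibition), compound 2 gives 88%; the only other number, from compound 1, sits within the scatter of it, the step being a number 1 percentage points lower from compound 1 to compound 2 (within the scatter). Compound 3 `O=Cc1c(-c2ccc(Cl)cc2)sc2ccccc12` is next: chloro in place of trifluoromethyl on an aromatic carbon. Among the compounds with values here, the one measured step, a number 1 percentage points lower from compound 1 to compound 2 (within the scatter), exchanged a group at the same place and left this assay unmoved; no step introducing chloro is known. Compound 3 is therefore expected to stay close, with an estimated step of a number 2 percentage points lower from compound 2 to compound 3 (within the scatter). The estimate for compound 3 is 86%, ranging from 74% to 95%.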

Compound 3, a percentage reported as inhibition, at one concentration (the size of the read-out at that concentration, not a potency): 67%
Compound 3: middle estimate off by 19 percentage points, on the high side, and the stated range ends above it.
By their numbers in this assay, from the lowest: compound 3; then compounds 2 and 1 (each within the scatter of the next).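

In this assay this aromatic carbon is not indifferent to its substituent: chloro gives a number 21 percentage points lower from compound 2 to compound 3 (beyond the scatter) and a number 22 percentage points lower from compound 1 to compound 3 (beyond the scatter) while methoxy and trifluoromethyl remain within the scatter of each other. Among these three compounds the change to chloro alone separates one compound from the others. No measurement available here explains the drop.

As far as these compounds go, whether bromo, an amine or a carboxylic acid on this carbon would track with chloro or with the other two groups remains open. From the compounds shown here alone, whether the drop extends beyond this one concentration and cell line is also open.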